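This account rests on a few compounds, and the source may have more. Where it says the series, first, only, none or still open, it means among the compounds named here.

Compound 1 `N=C(N)NCCC[C@H](NC(=O)CN(c1nc(Cl)nc2[nH]cnc12)C1CC1)C(=O)OCc1ccccc1` — 6.12%
Compound 2 `CC[C@H](C)[C@H](NC(=O)CN(c1ncnc2c1ncn2C1CCCCO1)C1CC1)C(=O)OCc1ccccc1` — 16.4%
Compound 3 `O=C(O)CNC(=O)CN(c1nc(Cl)nc2[nH]cnc12)C1CC1` — 9.08%

Of the compounds shown here, three have been measured in a functional assay on the whole organism (Tail, strain ICR) with Mus musculus as the target, in the tail flick test, with a stated time of 150 min, at a dose of 25 umol/kg by the oral route; a lower number here means a weaker effect, a higher number a stronger effect of the compound at the dose given. Among them compound 2 gives the highest number, 16.4%. Its nearest neighbour is compound 3, whose 9.08% lies within the usual scatter of the measurement, so the two cannot be told apart. Compound 1, with 6.12%, sits furthest away, and that gap lies beyond the scatter.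

Compound 4 `CC(C)(C)OC(=O)NCCCC[C@H](NC(=O)CN(c1ncnc2c1ncn2C1CCCCO1)C1CC1)C(=O)OCc1ccccc1` has not yet been measured in this assay. It differs from compound 2 in one place: 4-((tert-butoxycarbonyl)amino)butyl in place of sec-butyl on a saturated chain carbon bound to an amide-type nitrogen and a carbonyl carbon. Going by the values given here, no pair of measured compounds that differ in a single place is available, so the size of such a step is unknown from these data.

Given that the change is large and the three measured numbers all sit in a narrow band, compound 4 is expected to stay in the same region, and the step from compound 2 to compound 4 is estimated as a small decrease that may lie within the scatter, a number 4.4 percentage points lower from compound 2 to compound 4 (within the scatter). The estimate for compound 4 in this assay is 12%, with a range from 2% to 25%.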

Compound 4, a percentage reported as activity, at one dose (the size of the read-out at that dose, not a potency): 17.2%
Estimate against measurement, compound 4: 5.2 percentage points below, and the stated range covers the measured number.
By their numbers in this assay, from the lowest: compounds 1, 3, 2 and 4 (each within the scatter of the next, the first and the last beyond it).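

In this assay, going by these compounds alone, the first step that can be read at this position, a saturated chain carbon bound to an amide-type nitrogen and a carbonyl carbon, is a number 0.8 percentage points higher from compound 2 to compound 4 (within the scatter). The position thus takes 4-((tert-butoxycarbonyl)amino)butyl in place of sec-butyl, adding a hydrogen-bond donor and hydrogen-bond acceptors, without a difference that this measurement can resolve at the dose given. No measured property of these compounds bears on this result, and the data offer no explanation for it.

The compounds shown leave open whether this outcome would persist with a free primary amine at the end of the butyl chain, a carboxylic acid in that place, or a shorter or longer chain carrying the tert-butoxycarbonyl group. Also open, going by these compounds, is whether the same exchange would give a comparable result on the core of compound 1, and whether a dose series would separate compounds that a single dose and time cannot.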